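The source may report more compounds than this note shows. Statements on the series, on what has been measured and on what is new or still open speak of the compounds shown alone.

Of the compounds shown here, two sharing one core have been tested in an ADME assay on HEL cells (Homo sapiens) for cytotoxicity, read by microscopy; a lower number here means that less compound is tolerated, a higher number that more compound is tolerated. Compound 1 `COc1cc(C#CC#Cc2cn([C@H]3C[C@H](O)[C@@H](CO)O3)c(=O)[nH]c2=O)cc(OC)c1` carries a 3,5-dimethoxyphenyl group on a triple-bonded carbon. In this assay compound 1 reaches only > 100000 nM, which is a limit of the assay and not a number. Compound 2 `CC(O)CC#CC#Cc1cn([C@H]2C[C@H](O)[C@@H](CO)O2)c(=O)[nH]c1=O` has 2-hydroxypropyl in place of 3,5-dimethoxyphenyl on a triple-bonded carbon. In this assay compound 2 likewise stops at > 100000 nM, again a limit rather than a number. The step that the two limits leave unreadable from compound 1 to compound 2 therefore cannot be sized. Where compound 2 stands is known only as a limit, and the one other value shown is a limit too; both rest at the limit of > 100000 nM in this assay, at which 2 of the 2 values shown sit.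

Compound 3 `O=c1[nH]c(=O)n([C@H]2C[C@H](O)[C@@H](CO)O2)cc1C#CC#CC1CC1` is the next member, with cyclopropyl in place of 2-hydroxypropyl on a triple-bonded carbon. No measured step tells how exchanging a chain for a small ring here alters tolerance, since the only step shown is unreadable. The expectation is that compound 3 again shows no cytotoxicity up to the limit of this assay, so the step of a number no higher from compound 2 to compound 3 (the limit leaves the size open) is expected to be nil beyond the scatter. Compound 3 is estimated at 100000 nM, within 30000 nM to 300000 nM, most likely reported once more only as a limit.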

Compound 3, minimum cytotoxic concentration: > 100000 nM
Compound 3: a limit, no number; the forecaster's own chance of this, stated with the estimate: 85%; the middle value sits exactly at the limit.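

In this assay compound 3 gives > 100000 nM, which is a limit of the assay and not a number. The steps from compound 1 and from compound 2 to compound 3 therefore cannot be read: the limit of > 100000 nM in this assay, at which 3 of the 3 values shown sit. The compounds shown leave open at what concentration, if any, compound 1, compound 2 or compound 3 would become toxic to these cells.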